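The source may report more compounds than this note shows. Statements on the series, on what has been measured and on what is new or still open speak of the compounds shown alone.

Compound 1 `CN(c1ccc2cc(NC(=O)CCc3ccc(C(F)(F)F)cc3)ccc2n1)C1CCCC1` gives 350 nM; compound 2 `CC1CCN(c2ccc3cc(NC(=O)CCc4ccc(C(F)(F)F)cc4)ccc3n2)C1` gives 400 nM; compound 3 `CN(C)c1ccc2cc(NC(=O)CCc3ccc(C(F)(F)F)cc3)ccc2n1` gives 110 nM, all in a functional assay on HEK293 cells for activation of melanin-concentrating hormone receptor 1 (Rattus norvegicus), read by inositol phosphate accumulation; a lower number here means that less compound is needed, a higher number that more compound is needed for the effect.

Compound 3 stands lowest of the three numbers in this assay, with compound 1 nearest and compound 2 furthest, both beyond the scatter. Compound 4 `CNC(=O)NC1CCN(c2ccc3cc(NC(=O)CCc4ccc(C(F)(F)F)cc4)ccc3n2)C1` differs from compound 3 in one place: 3-((methylcarbamoyl)amino)pyrrolidin-1-yl in place of dimethylamino on an aromatic carbon. Going by the values given here, two measured steps bear on this. The step of a 3.6-fold lower number from compound 2 to compound 3 (0.56 log units; beyond the scatter) and the step of a 3.2-fold lower number from compound 1 to compound 3 (0.50 log units; beyond the scatter) both show that enlarging the amino group on this carbon of the core of compound 3 raised the number modestly. Compound 4 carries a still larger ring group there, so a modest rise is expected, a 4.1-fold higher number from compound 3 to compound 4 (0.61 log units; beyond the scatter). Compound 4 is therefore estimated at 450 nM, within a range of 150 nM to 1400 nM.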

Compound 4, half-maximal effective concentration: 30 nM
For compound 4 the middle estimate is 15-fold (1.18 log units) above the measured one; the whole stated range lies above it.
By their numbers in this assay, from the lowest: compound 4; then compound 3; then compounds 1 and 2 (each within the scatter of the next).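

In this assay, the group with the most heavy atoms so far on this aromatic carbon, 3-((methylcarbamoyl)amino)pyrrolidin-1-yl, does not raise the number but gives a 3.7-fold lower number from compound 3 to compound 4 (0.56 log units; beyond the scatter). Group size alone therefore does not set the number here: (methylcarbamoyl)amino in place of methyl on the saturated ring carbon gives a 13-fold lower number from compound 2 to compound 4 (1.12 log units; beyond the scatter), and the full group in place of cyclopentyl(methyl)amino gives a 12-fold lower number from compound 1 to compound 4 (1.07 log units; beyond the scatter). Nothing available explains this drop.

The compounds shown leave open whether a plain amine or an acetamide on that ring carbon would do the same, and whether a longer chain could replace the terminal methyl.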